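Dihydroxyphenyl hydrazone weighed against its bromo-hydroxy analogue

The source may hold more compounds than are shown below. What is called first, only, known or untested is meant among the compounds shown, and "the series" means these compounds.

In a functional assay on MCF7 cells (Homo sapiens) for inhibition, read by MTT assay, with a stated time of 48 h (on this read-out higher numbers stand for weaker inhibition and lower numbers for stronger inhibition), compound 3 `O=C(CSc1nnc(-c2ccncc2)n1-c1ccccc1)N/N=C/c1cc(Br)ccc1O` gives 6460 nM, the lowest of the two numbers shown. Compound 1 `O=C(CSc1nnc(-c2ccncc2)n1-c1ccccc1)N/N=C/c1ccc([N+](=O)[O-])cc1` gives 15300 nM, so the step of a 2.4-fold lower number from compound 1 to compound 3 (0.37 log units; beyond the scatter) is beyond the scatter. Compound 2 `O=C(CSc1nnc(-c2ccncc2)n1-c1ccccc1)N/N=C/c1ccc(O)cc1` reaches only a limit in this assay, > 50000 nM. This is the limit of > 50000 nM in this assay, at which 1 of the 3 values shown sits.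

Compound 4 `O=C(CSc1nnc(-c2ccncc2)n1-c1ccccc1)N/N=C/c1ccc(O)c(O)c1` differs from compound 3 by 3,4-dihydroxyphenyl in place of 5-bromo-2-hydroxyphenyl on a carbon with a double bond to nitrogen. Among the measured compounds shown here, two measured steps bear on this change. The step of an at least 3.2-fold higher number from compound 1 to compound 2 (0.51 log units; beyond the scatter) shows that a hydroxy-bearing phenyl without further substitution gave only a limit, and the step of an at least 7.7-fold lower number from compound 2 to compound 3 (0.88 log units; beyond the scatter) shows that the 5-bromo-2-hydroxyphenyl of compound 3 brought the number down from that limit. Compound 4 returns to a phenyl carrying hydroxy groups and no bromine, closer to compound 2 than to compound 3, so a higher number is expected, with a fair chance that only a limit is returned.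

Compound 4 is therefore expected to give 25000 nM, within 9000 nM to 60000 nM. This estimate means a step of a 3.9-fold higher number from compound 3 to compound 4 (0.59 log units; beyond the scatter) in this assay.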

Compound 4, half-maximal inhibitory concentration: 19700 nM
Estimate against measurement, compound 4: 1.3-fold (0.10 log units) above, and the stated range covers the measured number.
By their numbers in this assay, from the lowest: compound 3; then compounds 1 and 4 (each within the scatter of the next). At a limit, above all of these: compound 2.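

Compound 2 stands only at a limit in this assay, and the 3,4-dihydroxyphenyl group on the carbon with a double bond to nitrogen brings the series off that limit: an at least 2.5-fold lower number from compound 2 to compound 4 (0.40 log units; beyond the scatter). The extra hydroxy does not match the 5-bromo-2-hydroxyphenyl group, however, as a 3.0-fold higher number from compound 3 to compound 4 (0.48 log units; beyond the scatter) shows, so compound 3 remains clear of this new phenyl. Compound 4 also cannot be told apart from the 4-nitrophenyl analogue, with a 1.3-fold higher number from compound 1 to compound 4 (0.11 log units; within the scatter), although the two groups share no substituent.

The compounds shown do not separate the contribution of the bromine in compound 3 from that of its hydroxy placement. Also open, as far as these compounds go, is how a chlorine, a methoxy or an amine on this phenyl would read out.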